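Methoxy to cyclopentyloxy: a repeated step in the series

This account rests on a few compounds, and the source may have more. Where it says the series, first, only, none or still open, it means among the compounds named here.

Measured compounds:
compound 1 `COc1ccc(/C=C2\NC(=O)N(CCCN3CCN(c4cccc(Cl)c4Cl)CC3)C2=O)cc1OC`: 22 nM
compound 2 `COc1ccc(/C=C2\NC(=O)N(CCCCN3CCN(c4ccccc4OC)CC3)C2=O)cc1OC`: 16 nM
compound 3 `COc1ccc(/C=C2\NC(=O)N(CCCN3CCN(c4cccc(Cl)c4Cl)CC3)C2=O)cc1OC1CCCC1`: 380 nM

In an assay on CHO cells for displacement of a labelled ligand from 5-hydroxytryptamine receptor 7 (Homo sapiens), read by scintillation counting, with a stated time of 60 min (on this read-out higher numbers stand for weaker inhibition and lower numbers for stronger inhibition), compound 1 gives 22 nM, compound 2 gives 16 nM and compound 3 gives 380 nM. Compound 3 differs from compound 1 by cyclopentyl in place of methyl on an oxygen on an aromatic ring; that step is a 17-fold higher number from compound 1 to compound 3 (1.24 log units; beyond the scatter). The difference between the cores of compound 1 and compound 2 is not broken down here; their two values lie within the scatter of each other.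

Compound 4 `COc1ccc(/C=C2\NC(=O)N(CCCCN3CCN(c4ccccc4OC)CC3)C2=O)cc1OC1CCCC1` has not been measured. It differs from compound 2 by cyclopentyl in place of methyl on an oxygen on an aromatic ring, the same change at the same place as between compound 1 and compound 3. On this assay the step from compound 2 to compound 4 is expected to be a 16-fold higher number from compound 2 to compound 4 (1.19 log units; beyond the scatter), set beside a 17-fold higher number from compound 1 to compound 3 (1.24 log units; beyond the scatter), and rests on that single measured instance alone. Compound 4 is accordingly estimated at 250 nM, expected between 80 nM and 800 nM.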

Compound 4, inhibition constant: 1 nM
Estimate against measurement, compound 4: 250-fold (2.40 log units) above, outside the stated range (below it).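

In this assay, cyclopentyl in place of methyl on an oxygen on an aromatic ring gives a 16-fold lower number from compound 2 to compound 4 (1.20 log units; beyond the scatter), in the opposite direction to the earlier step. The change therefore does not carry from one core to the other in this series, and its outcome depends on the core that bears it: the same change on two cores in this assay, a 17-fold higher number (1.24 log units; beyond the scatter) from compound 1 to compound 3 and a 16-fold lower number (1.20 log units; beyond the scatter) from compound 2 to compound 4, 280-fold (2.44 log units) apart, beyond the scatter of two such steps The two pairs do not show which part of the difference between the cores decides the direction, and they give no rule for any third core.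

Still open, on these data alone, is how an ethyl or a cyclohexyl group on the same oxygen behaves on each core. Also open, as far as these compounds go, is whether the core of compound 1 with a butyl chain would follow compound 2 or compound 1.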